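The source may report more compounds than this note shows. Statements on the series, on what has been measured and on what is new or still open speak of the compounds shown alone.

Measured compounds:
Compound 1 `C[C@@H]1CN(C(=O)c2nc(Nc3cc(C4CC4)[nH]n3)c3cc(Cl)ccc3n2)CCN1C(=O)OC(C)(C)C`, in a physicochemical assay, read by HPLC, in phosphate buffer, with a stated time of 2 h, at pH 7.4 (on this read-out lower numbers stand for a less stable compound and higher numbers for a more stable compound), compound 1 gives 99.1%.
Compound 2 `CCCCCOC(=O)N1CCN(C(=O)c2nc(Nc3cc(C4CC4)[nH]n3)c3cc(Cl)ccc3n2)C[C@H]1C`: compound 2 gives 99.8%.
Compound 3 `CC(OC(=O)C(C)C)OC(=O)N1CCN(C(=O)c2nc(Nc3cc(C4CC4)[nH]n3)c3cc(Cl)ccc3n2)C[C@H]1C`: compound 3 gives 96.6%.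

Compound 3 carries the lowest of the three values, yet the steps reaching it are small: a number 2.5 percentage points lower from compound 1 to compound 3 (within the scatter) and a number 3.2 percentage points lower from compound 2 to compound 3 (within the scatter), both within the scatter. The step of a number 0.7 percentage points higher from compound 1 to compound 2 (within the scatter) is likewise within the scatter. Across all three the group on the oxygen of the carbamate was exchanged without any change beyond the scatter in this assay.

Compound 4 `C[C@@H]1CN(C(=O)c2nc(Nc3cc(C4CC4)[nH]n3)c3cc(Cl)ccc3n2)CCN1C(=O)OCOC(=O)C(C)(C)C` differs from compound 3 in the same place: (((tert-butyl)carbonyl)oxy)methyl in place of 1-((isopropylcarbonyl)oxy)ethyl on an oxygen next to a carbonyl group. Within the data shown here, the steps that bear on this change are those in which this oxygen-bound group was exchanged, from compound 1 to compound 2, from compound 1 to compound 3 and from compound 2 to compound 3, none of which left the scatter. Compound 4 is therefore expected to show no step beyond the scatter, an estimated a number 0.9 percentage points higher from compound 3 to compound 4 (within the scatter). For compound 4 the estimated value in this assay is 97.5%, with a range from 92% to 100%.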

Compound 4, percent of the compound remaining: 97.7%
Compound 4: the middle estimate sits 0.2 percentage points below what was measured; low and high end bracket the measured number.
By their numbers in this assay, from the lowest: compounds 3, 4, 1 and 2 (each within the scatter of the next).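

On the oxygen next to a carbonyl group, (((tert-butyl)carbonyl)oxy)methyl in place of 1-((isopropylcarbonyl)oxy)ethyl, two groups with the same count of heavy atoms and no ring, gives a number 1.1 percentage points higher from compound 3 to compound 4 (within the scatter) in this assay. The comparison with the simpler groups on this oxygen reads a number 1.4 percentage points lower from compound 1 to compound 4 (within the scatter) and a number 2.1 percentage points lower from compound 2 to compound 4 (within the scatter), so two different ester-bearing groups now sit within the scatter of both tert-butyl and pentyl at this position. No independent measurement accounts for this flat picture.

The compounds shown leave open how an amine, a carboxylic acid or a chain longer than pentyl on this oxygen would read in this assay. They also leave open whether these four carbamates stay this close to one another over a longer time or at another pH.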